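The source may hold more compounds than are shown below. What is called first, only, known or untested is meant among the compounds shown, and "the series" means these compounds.

Of the compounds shown here, two have numbers so far. In a functional assay on HepG2 cells (Homo sapiens) for inhibition, read by MTT assay, with a stated time of 72 h (on this read-out higher numbers stand for weaker inhibition and lower numbers for stronger inhibition), compound 1 (`Brc1ccccc1-c1nc(-c2ccccc2)co1`) reads 16900 nM and compound 2 (`CC(=O)Oc1ccc(-c2nc(-c3ccccc3)co2)cc1`) reads 16700 nM in the same test, within the scatter of each other, so compound 1 stands level with compound 2 and neither can be ranked. Compound 3 (`O=[N+]([O-])c1ccccc1-c1nc(-c2ccccc2)co1`) has not yet been measured. It departs from compound 1 in one place, with nitro in place of bromo on an aromatic carbon, ortho to a large group (nitro in place of bromo on an aromatic carbon). Among the measured compounds shown here, no measured pair differing in one place is available, so the data give no direct guide to the size of this change. Compound 1 at 16900 nM is the only anchor for the expectation, and no step beyond the scatter is expected in this assay in either direction. The estimated step (a 1.1-fold lower number from compound 1 to compound 3 (0.05 log units; within the scatter)) is accordingly expected to be small. Two values are a thin basis, so the range is kept wide. For compound 3 the expected value is 15000 nM with an estimated range from 6000 nM to 40000 nM once it is tested.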

Compound 3, half-maximal inhibitory concentration: 56500 nM
Estimate against measurement, compound 3: 3.8-fold (0.58 log units) below; measured number outside the range, above it.
By their numbers in this assay, from the lowest: compounds 2 and 1 (each within the scatter of the next); then compound 3.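

In this assay, among the compounds shown here, this is the only step between two measured compounds that differ in one place, and it shows that the position on the aromatic carbon, ortho to a large group, does respond to what sits there: nitro in place of bromo gives a 3.3-fold higher number from compound 1 to compound 3 (0.52 log units; beyond the scatter). The exchange replaces one heavy atom with three and brings in two hydrogen-bond acceptors where bromo has none, and the higher number stands for weaker inhibition, so this change moves the compound toward weaker inhibition by more than the scatter. No measurement here speaks to what lies behind the step.

The compounds shown leave open whether the step goes with the added heavy atoms, with the acceptors or with neither, as only this one replacement at the position can be read. From the compounds shown here alone, how an amine, a methoxy group or a fluorine atom at the same place would read against compound 1 remains open, as does whether nitro on another carbon of this ring would give a step of similar size.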